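Growing a small chain and what the cells tolerate

A few compounds are considered here, and "the series" means these few. Any claim that something is new, unique, unknown or untested is made for them only; others in the source may bear on it.

Three compounds share one core and differ only in a small group attached to it. Compound 1 `Cc1nc[nH]c1CN[C@@H]1C[C@@H]2C[C@H]([C@H]1C)C2(C)C`, compound 2 `CCc1nc[nH]c1CN[C@@H]1C[C@@H]2C[C@H]([C@H]1C)C2(C)C` and compound 3 `CC(C)c1ncc(CN[C@@H]2C[C@@H]3C[C@H]([C@H]2C)C3(C)C)[nH]1` were tested in an ADME assay on MDCK cells (Canis lupus familiaris) for cytotoxicity, read by MTT assay, with a stated time of 48 h; a lower number here means that less compound is tolerated, a higher number that more compound is tolerated. Compound 1 gives 252000 nM, compound 2 gives 180000 nM, and compound 3 gives 114000 nM, the lowest of the three. The step of a 1.4-fold lower number from compound 1 to compound 2 (0.15 log units; within the scatter) comes from methyl in place of hydrogen on a saturated chain carbon bound to an aromatic carbon. How the core of compound 3 differs from that of compound 1 is not broken down here; their two values differ beyond the scatter.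

Compound 4 `C[C@@H]1[C@H]2C[C@@H](C[C@H]1NCc1cnc(C(C)(C)C)[nH]1)C2(C)C` has not yet been measured in this assay. It differs from compound 3 by methyl in place of hydrogen on a saturated chain carbon bound to an aromatic carbon and two saturated chain carbons, the same kind of change as that from compound 1 to compound 2, though here the carbon also carries two saturated chain carbons. Because the step of a 1.4-fold lower number from compound 1 to compound 2 (0.15 log units; within the scatter) was small and within the scatter, the expected step of a 1.3-fold lower number from compound 3 to compound 4 (0.13 log units; within the scatter) is likewise modest. Compound 4 is therefore estimated at 85000 nM, with a range from 45000 nM to 160000 nM.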

Compound 4, half-maximal cytotoxic concentration: 107000 nM
Compound 4: middle estimate off by 1.3-fold (0.10 log units), on the low side, within the range that was stated.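

Placing methyl in place of hydrogen on a saturated chain carbon bound to an aromatic carbon and two saturated chain carbons, which turns isopropyl into tert-butyl, gives a 1.1-fold lower number from compound 3 to compound 4 (0.03 log units; within the scatter) in this assay. Set beside the earlier step, the change reads alike on the two cores, with no gap that the scatter cannot account for: the same change on two cores in this assay, a 1.4-fold lower number (0.15 log units; within the scatter) from compound 1 to compound 2 and a 1.1-fold lower number (0.03 log units; within the scatter) from compound 3 to compound 4, 1.3-fold (0.12 log units) apart, within the scatter of two such steps. Within these two pairs, then, the change carries from one core to the other without a detectable shift, but each step is itself within the scatter, so this shows neither that the added methyl has a real effect on what the cells tolerate nor that the agreement would hold on any further core.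

The compounds shown carry only small saturated chains, from methyl to tert-butyl. From the compounds shown here alone, how a longer chain, an amine or a carboxylic acid in place of these groups would read in this assay stays open.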